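Methyl to hydrogen on an aryl ether: predicting compound 4

The source may hold more compounds than are shown below. What is called first, only, known or untested is meant among the compounds shown, and "the series" means these compounds.

Measured compounds:
- Compound 1, `COc1cc(-c2nn(-c3cccc(NC(=O)Nc4ccc(Cl)c(Cl)c4)c3)cc2-c2ccncc2)ccc1Cl`, gives 937 nM in a functional assay on COLO 205 cells (Homo sapiens) for inhibition, read by sulforhodamine B assay, with a stated time of 48 h; on this read-out higher numbers stand for weaker inhibition of growth and lower numbers for stronger inhibition of growth.
- Compound 2, `O=C(Nc1cccc(-n2cc(-c3ccncc3)c(-c3ccc(Cl)c(O)c3)n2)c1)Nc1ccc(Cl)c(Cl)c1`, gives 3960 nM in this assay.
- Compound 3, `COc1cc(-c2nn(-c3cccc(NC(=O)Nc4ccc(Cl)c(C(F)(F)F)c4)c3)cc2-c2ccncc2)ccc1Cl`, gives 711 nM in this assay.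

Compounds 1 and 2 share a core and differ only by hydrogen in place of methyl on an oxygen on an aromatic ring. That change produced a 4.2-fold higher number from compound 1 to compound 2 (0.63 log units; beyond the scatter), a step beyond the scatter. Compounds 1 and 3 differ by trifluoromethyl in place of chloro on an aromatic carbon, and the result was a 1.3-fold lower number from compound 1 to compound 3 (0.12 log units; within the scatter), so these two compounds cannot be ranked against each other.

Compound 4, `O=C(Nc1cccc(-n2cc(-c3ccncc3)c(-c3ccc(Cl)c(O)c3)n2)c1)Nc1ccc(Cl)c(C(F)(F)F)c1`, has not yet been measured. It relates to compound 3 exactly as compound 2 relates to compound 1: the difference is hydrogen in place of methyl on an oxygen on an aromatic ring, on the same place as before, while the two cores themselves differ by trifluoromethyl in place of chloro on an aromatic carbon. Because the earlier step was a 4.2-fold higher number from compound 1 to compound 2 (0.63 log units; beyond the scatter), the same change on the core of compound 3 is expected to give a step of about a 4.2-fold higher number from compound 3 to compound 4 (0.63 log units; beyond the scatter) in this assay. This rests on a single earlier pair, so the expectation carries real uncertainty. Compound 4 is therefore estimated at 3000 nM, with a likely range from 1200 nM to 7500 nM.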

Compound 4, concentration for 50% growth inhibition: 2390 nM
Compound 4: middle estimate off by 1.3-fold (0.10 log units), on the high side; the range from low to high includes it.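

Replacing methoxy with hydroxy on the core of compound 3 gave a 3.4-fold higher number from compound 3 to compound 4 (0.53 log units; beyond the scatter) in this assay, and this step agrees with the one seen earlier on the core of compound 1: the same change on two cores in this assay, a 4.2-fold higher number (0.63 log units; beyond the scatter) from compound 1 to compound 2 and a 3.4-fold higher number (0.53 log units; beyond the scatter) from compound 3 to compound 4, 1.3-fold (0.10 log units) apart, within the scatter of two such steps. Trifluoromethyl in place of chloro, now read with the hydroxy group present, gave a 1.7-fold lower number from compound 2 to compound 4 (0.22 log units; within the scatter), so this change again does not separate the two compounds it links, and the two readings of it agree: the same change on two cores in this assay, a 1.3-fold lower number (0.12 log units; within the scatter) from compound 1 to compound 3 and a 1.7-fold lower number (0.22 log units; within the scatter) from compound 2 to compound 4, 1.3-fold (0.10 log units) apart, within the scatter of two such steps. Within these four compounds the two changes therefore carry over from one core to the other, but this rests on just two cores and one cell assay, so it shows neither that the same would hold on a different core nor why growth inhibition changes.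

The compounds shown leave open how far the oxygen substituent can be varied, for example whether a longer chain such as ethoxy would keep the level of compound 1 or lose ground as hydroxy does. They also leave open whether an amine in place of the methoxy would behave like the hydroxy group in this assay.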